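Dimethylamino in Place of Nitro on the Shared Core

A few compounds are considered here, and "the series" means these few. Any claim that something is new, unique, unknown or untested is made for them only; others in the source may bear on it.

Compound 1 `COC(=O)C1=C(C)NC(=O)NC1c1ccc(OC)cc1`: 59200 nM
Compound 2 `COC(=O)C1=C(C)NC(=O)NC1c1ccc(Cl)cc1`: 34200 nM
Compound 3 `COC(=O)C1=C(C)NC(=O)NC1c1ccc([N+](=O)[O-])cc1`: 49100 nM

Three compounds share one core and differ only in the group carried by the aromatic ring. In an assay for inhibition of beta-glucuronidase (Bos taurus), read by spectrophotometry, with a stated time of 30 min (a higher number here means a weaker inhibitor, a lower number a stronger inhibitor), compound 3 gives 49100 nM, a number that sits close to the other two: the step of a 1.2-fold lower number from compound 1 to compound 3 (0.08 log units; within the scatter) and the step of a 1.4-fold higher number from compound 2 to compound 3 (0.16 log units; within the scatter) are both within the scatter, so compound 3 cannot be placed above or below either neighbour with confidence.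

Compound 4 `COC(=O)C1=C(C)NC(=O)NC1c1ccc(N(C)C)cc1` is the next member. Its difference from compound 3 is dimethylamino in place of nitro on an aromatic carbon. Among the compounds with values here, no measured pair shows this exact exchange, but all three measured steps concern the same site on the ring: a 1.7-fold lower number from compound 1 to compound 2 (0.24 log units; within the scatter), a 1.2-fold lower number from compound 1 to compound 3 (0.08 log units; within the scatter) and a 1.4-fold higher number from compound 2 to compound 3 (0.16 log units; within the scatter). Methoxy, chloro and nitro at that site gave numbers that differ by less than the scatter in this assay.

On that record the step to compound 4 is expected to be small as well, because the comparable exchanges a 1.2-fold lower number from compound 1 to compound 3 (0.08 log units; within the scatter) and a 1.4-fold higher number from compound 2 to compound 3 (0.16 log units; within the scatter) stayed within the scatter, giving an estimated step of a 1.1-fold lower number from compound 3 to compound 4 (0.04 log units; within the scatter) in this assay. Compound 4 is therefore estimated at 45000 nM, with a range from 18000 nM to 110000 nM.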

Compound 4, half-maximal inhibitory concentration: 49200 nM
Estimate against measurement, compound 4: 1.1-fold (0.04 log units) below; the measured number falls inside the stated range.
By their numbers in this assay, from the lowest: compounds 2, 3, 4 and 1 (each within the scatter of the next).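

In this assay the exchange of nitro for dimethylamino, on an aromatic carbon para to a large group, gives a 1.0-fold higher number from compound 3 to compound 4 (0.00 log units; within the scatter) and so leaves the number unmoved within the scatter, even though the two groups share only their size of 3 heavy atoms and differ in what those atoms are. Compound 4 also shows a 1.4-fold higher number from compound 2 to compound 4 (0.16 log units; within the scatter) and a 1.2-fold lower number from compound 1 to compound 4 (0.08 log units; within the scatter) as its remaining steps, so a fourth group at this site joins the other three with no step beyond the scatter, and no ranking of methoxy, chloro, nitro and dimethylamino can be drawn from these numbers. Nothing measured alongside these compounds offers an explanation for this flat result.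

Still open, going by these compounds, is whether a group of another kind at this site, such as a carboxylic acid, a hydroxyl or a longer alkyl chain, would move the number beyond the scatter. Also open, on these data alone, is whether a change elsewhere on the shared core, such as an amide in place of the methyl ester, would separate compounds that this ring site does not.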